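Solubility notes on a shared core: phenethyl for methoxyphenoxy

The source may report more compounds than this note shows. Statements on the series, on what has been measured and on what is new or still open speak of the compounds shown alone.

Measured so far:
- compound 1 `COc1ccccc1Oc1ccc2c(NCCCNCc3ccco3)ccnc2c1`: 14500 nM
- compound 2 `CCC(CC)c1ccc2c(NCCCNCc3cccc(OC)c3O)ccnc2c1`: 4200 nM
- compound 3 `COc1cccc(Oc2ccc3c(NCCCNCc4cccc(OC)c4O)ccnc3c2)c1`: 14500 nM

In a physicochemical assay for solubility, with a stated time of 18 h, at pH 7.4 (on this read-out lower numbers stand for lower solubility and higher numbers for higher solubility), compound 1 gives 14500 nM, level with compound 3 at the digits shown and together with it the highest of the three numbers; compound 2 lies furthest away, with the lower number 4200 nM.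

Compound 4 `c1ccc(CCc2ccc3c(NCCCNCc4ccco4)ccnc3c2)cc1` has not been measured in this assay. It differs from compound 1 in one place: phenethyl in place of 2-methoxyphenoxy on an aromatic carbon. The group that leaves carries two hydrogen-bond acceptors; the group that enters carries none.

Going by the values given here, the one measured step that bears on this is a 3.5-fold higher number from compound 2 to compound 3 (0.54 log units; beyond the scatter), in which a carbon-only group on the same position of the core was exchanged for a methoxyphenoxy group and the number rose. Compounds 2 and 3 carry a different side chain from compounds 1 and 4, so the step is an analogy, not a repeat. Read in the reverse direction, from a methoxyphenoxy group to a carbon-only group, it suggests a drop of similar size for compound 4.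

Compound 4 is therefore expected to give 4500 nM in this assay, with a range of 1800 nM to 11000 nM, the estimated step being a 3.2-fold lower number from compound 1 to compound 4 (0.51 log units; beyond the scatter).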

Compound 4, solubility: 4200 nM
For compound 4 the middle estimate is 1.1-fold (0.03 log units) above the measured one, within the range that was stated.
By their numbers in this assay, from the lowest: compounds 2 and 4 (each within the scatter of the next); then compounds 1 and 3 (each within the scatter of the next).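

In this assay, going by these compounds alone, the exchange of 2-methoxyphenoxy for phenethyl gives a 3.5-fold lower number from compound 1 to compound 4 (0.54 log units; beyond the scatter) and is the first direct reading of this change on the side chain of compound 1. Phenethyl keeps the six-membered aromatic ring of carbon only, so the step is seen with that ring present on both sides, which the earlier pair could not show, since pentan-3-yl has no ring. Read against a 3.5-fold higher number from compound 2 to compound 3 (0.54 log units; beyond the scatter), which has the same printed size in the opposite direction, both pairs place the carbon-only group at the lower number and the methoxyphenoxy group at the higher one, with neither pair going against this, though nothing at hand bears on the reason for the shift.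

The compounds shown do not separate the ether oxygen from the methoxy group, a question that an unsubstituted phenoxy group or a phenethyl group carrying a methoxy group would address. Also open, on these data alone, is how an amine such as morpholine or a carboxylic acid at this position would read against compound 1 and compound 4 on the same side chain.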